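From iodo to benzofuranyl on a shared nucleoside core

The source may report more compounds than this note shows. Statements on the series, on what has been measured and on what is new or still open speak of the compounds shown alone.

Compound 3 `COc1ncnc2c1c(I)cn2[C@@H]1O[C@H](CO)[C@@H](O)[C@H]1O` was tested in a functional assay on HepG2 cells (Homo sapiens) for antiproliferative activity, read by XTT assay, with a stated time of 72 h; a lower number here means a stronger inhibitor, a higher number a weaker inhibitor. In this assay compound 3 gives only the limit > 20000 nM, which is a bound of the assay and not a number. Compound 1 `COc1ncnc2c1c(-c1cccs1)cn2[C@@H]1O[C@H](CO)[C@@H](O)[C@H]1O` gives 13900 nM in this assay, and compound 2 `C#Cc1cn([C@@H]2O[C@H](CO)[C@@H](O)[C@H]2O)c2ncnc(OC)c12` gives 12700 nM. Both steps toward iodo, an at least 1.4-fold higher number from compound 1 to compound 3 (0.15 log units; that floor lies within the scatter) and an at least 1.5-fold higher number from compound 2 to compound 3 (0.19 log units; that floor lies within the scatter), end at the limit of > 20000 nM in this assay, at which 1 of the 3 values shown sits. Compound 4 `COc1ncnc2c1c(-c1cc3ccccc3o1)cn2[C@@H]1O[C@H](CO)[C@@H](O)[C@H]1O` carries 1-benzofuran-2-yl in place of iodo on an aromatic carbon. The change runs opposite to the two measured steps, putting a ring group back where iodo sat. Compound 4 is therefore expected to show a step of an at least 1.6-fold lower number from compound 3 to compound 4 (0.22 log units; that floor lies within the scatter) because an at least 1.4-fold higher number from compound 1 to compound 3 (0.15 log units; that floor lies within the scatter) ran the other way. Compound 4 is estimated at 12000 nM, within 5000 nM to 25000 nM.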

Compound 4, half-maximal inhibitory concentration: > 20000 nM
Compound 4: only a limit was reported; the forecaster's own chance of this, stated with the estimate: 35%; middle value at least 1.6-fold (0.22 log units) from the limit.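

In this assay, compound 4 shows that an aromatic ring group at this position does not by itself give a value short of the limit, as the thiophen-2-yl of compound 1 did; its own value is a limit, as is that of compound 3, so the step between those two cannot be read. The readable steps are an at least 1.5-fold higher number from compound 2 to compound 4 (0.19 log units; that floor lies within the scatter) and an at least 1.4-fold higher number from compound 1 to compound 4 (0.15 log units; that floor lies within the scatter), so neither separates 1-benzofuran-2-yl from the other group. The series now meets this limit twice: the limit of > 20000 nM in this assay, at which 2 of the 4 values shown sit.

From the compounds shown here alone, how far compound 3 and compound 4 lie past the limit stays open. So does how an amine or a longer alkyl chain would read at this position.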